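The source may hold more compounds than are shown below. What is called first, only, known or untested is meant among the compounds shown, and "the series" means these compounds.

Of the compounds shown here, three sharing one core have been tested in a functional assay on PC-3 cells (Homo sapiens) for cytotoxicity, read by MTT assay, with a stated time of 72 h; a lower number here means a stronger inhibitor, a higher number a weaker inhibitor. There, compound 1 `COc1ccc(OC)c(/C=C/C(=O)Nc2cc3c(Nc4ccc(F)c(Cl)c4)ncnc3cc2OC)c1` gives 28600 nM and compound 3 `COc1ccc(/C=C/C(=O)Nc2cc3c(Nc4ccc(F)c(Cl)c4)ncnc3cc2OC)c(OC)c1` gives 38500 nM, while compound 2 `COc1ccc(/C=C/C(=O)Nc2cc3c(Nc4ccc(F)c(Cl)c4)ncnc3cc2OC)cc1` is recorded as "not active" (no number reported), with no number. Among the measured compounds shown here, compound 3 therefore stands level, within the scatter, with compound 1, the only other compound that has a number. Compound 4 `COc1cc(/C=C/C(=O)Nc2cc3c(Nc4ccc(F)c(Cl)c4)ncnc3cc2OC)cc(OC)c1` has not yet been measured. It differs from compound 3 in one group, on a double-bonded chain carbon bound to a double-bonded chain carbon: 3,5-dimethoxyphenyl in place of 2,4-dimethoxyphenyl on a double-bonded chain carbon bound to a double-bonded chain carbon. For the measured compounds named here, only one measured step bears directly on this change. Replacing 2,5-dimethoxyphenyl with 2,4-dimethoxyphenyl gave a 1.3-fold higher number from compound 1 to compound 3 (0.13 log units; within the scatter), so that swap of one dimethoxyphenyl group for another left this assay within the scatter. On that basis, no change beyond the scatter is expected for the new swap, although a single step is thin evidence. Compound 2, recorded as "not active" (no number reported), also shows that a compound in this small set may yield no number at all, so that outcome remains possible. The expected 1.1-fold lower number from compound 3 to compound 4 (0.04 log units; within the scatter) is accordingly small, with no firm direction. For compound 4 the estimated value is 35000 nM, with an expected range from 15000 nM to 80000 nM.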

Compound 4, half-maximal inhibitory concentration: "not active" (no number reported)
Compound 4 has no reported number here; there is nothing to compare the estimate with.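

In this assay compound 4 is recorded without a number, so no step can be read from compound 3 to compound 4. No measurement shown here accounts for this result. The compounds shown leave open how far the 3,5-dimethoxyphenyl group of compound 4 separates it from compound 3, which carries the 2,4-dimethoxyphenyl group.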